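Nitro for trifluoromethyl on an amide-linked pyrazole series

The compounds below may be only part of what the source reports. "The series", "measured", "known", "first", "only" and "open" are said of these compounds alone.

Compound 1 `O=C(Nc1cc(-c2ccccc2)nn1-c1ccccc1)c1ccccc1`: 4180 nM
Compound 2 `COc1cccc(C(=O)Nc2cc(-c3ccccc3)nn2-c2ccccc2)c1`: 1290 nM
Compound 3 `O=C(Nc1cc(-c2ccccc2)nn1-c1ccccc1)c1cccc(C(F)(F)F)c1`: 1650 nM

In an assay on HEK293 cells for displacement of a labelled ligand from metabotropic glutamate receptor 5 (Rattus norvegicus) (a higher number here means a weaker inhibitor, a lower number a stronger inhibitor), compound 3 gives 1650 nM, the second highest of the three numbers; it sits within the scatter of compound 2 and beyond it only against compound 1. Compound 4 `O=C(Nc1cc(-c2ccccc2)nn1-c1ccccc1)c1cccc([N+](=O)[O-])c1` differs from compound 3 by nitro in place of trifluoromethyl on an aromatic carbon. For the measured compounds named here, two steps bear on this: a 2.5-fold lower number from compound 1 to compound 3 (0.40 log units; beyond the scatter) and a 3.2-fold lower number from compound 1 to compound 2 (0.51 log units; beyond the scatter) show that a group at this position gives a modest gain over hydrogen, while a 1.3-fold higher number from compound 2 to compound 3 (0.11 log units; within the scatter) shows that exchanging one such group for another changes little. Compound 4 is therefore expected to stay close to compound 3, with a 1.1-fold lower number from compound 3 to compound 4 (0.04 log units; within the scatter) inside the scatter. Compound 4 is estimated at 1500 nM, between 600 nM and 4000 nM.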

Compound 4, inhibition constant: 2220 nM
Compound 4: the middle estimate sits 1.5-fold (0.17 log units) below what was measured; low and high end bracket the measured number.
By their numbers in this assay, from the lowest: compounds 2, 3, 4 and 1 (each within the scatter of the next, the first and the last beyond it).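

In this assay nitro in this place cannot be told apart from trifluoromethyl (a 1.3-fold higher number from compound 3 to compound 4 (0.13 log units; within the scatter)) or from methoxy (a 1.7-fold higher number from compound 2 to compound 4 (0.24 log units; within the scatter)). It also cannot be told apart from hydrogen (a 1.9-fold lower number from compound 1 to compound 4 (0.27 log units; within the scatter)), so, unlike methoxy and trifluoromethyl, nitro shows no gain over hydrogen beyond the scatter, and the earlier gain is not shared by every group tried here. No measurement is available that explains this result. Going by these compounds, it remains open whether an amine or a carboxylic acid in the same place would give a step beyond the scatter from compound 3.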